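A few compounds are considered here, and "the series" means these few. Any claim that something is new, unique, unknown or untested is made for them only; others in the source may bear on it.

Measured compounds:
compound 1 `CCCCCCCCCCCC(=O)O[C@H]1[C@@H](O[C@]2(COC(C)=O)O[C@H](CO)[C@@H](O)[C@@H]2OCC(C)C)O[C@H](CO)[C@@H](O)[C@@H]1OCC(C)C`: 260 nM
compound 2 `CCCCCCCCCCCC(=O)O[C@H]1[C@@H](O[C@]2(COC(C)=O)O[C@H](CO)[C@@H](O)[C@@H]2O)O[C@H](CO)[C@@H](O)[C@@H]1OCC(C)C`: 340 nM

In a functional assay on the whole organism (Ear, strain NIH) for inhibition, with Mus musculus as the target (a lower number here means a stronger inhibitor, a higher number a weaker inhibitor), compound 1 gives 260 nM and compound 2 gives 340 nM; the step of a 1.3-fold higher number from compound 1 to compound 2 (0.12 log units; within the scatter) leaves the two level. Compound 3 `CCCCCCCCCCCC(=O)O[C@H]1[C@@H](O[C@]2(CO)O[C@H](CO)[C@@H](O)[C@@H]2OCC(C)C)O[C@H](CO)[C@@H](O)[C@@H]1OCC(C)C` differs from compound 1 in this way: hydrogen in place of acetyl on an oxygen on a saturated carbon. For the measured compounds named here, the only measured step, a 1.3-fold higher number from compound 1 to compound 2 (0.12 log units; within the scatter), also removes a group from an oxygen on a saturated carbon and stayed within the scatter, so no larger move is expected here either. Compound 3 is expected to show a 1.2-fold higher number from compound 1 to compound 3 (0.06 log units; within the scatter). The estimate for compound 3 is 300 nM, with a range from 130 nM to 700 nM.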

Compound 3, half-maximal inhibitory concentration: 350 nM
The estimate for compound 3 lay 1.2-fold (0.07 log units) below the measured number, and the stated range covers the measured number.
By their numbers in this assay, from the lowest: compounds 1, 2 and 3 (each within the scatter of the next).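

Going from acetoxymethyl to hydroxymethyl gives a 1.3-fold higher number from compound 1 to compound 3 (0.13 log units; within the scatter) in this assay, so the acetyl on this oxygen is not needed to keep the number in the range of compound 1. The earlier step showed this only for an isobutyl at another oxygen, and now a second place on the core can lose its group with no step beyond the scatter.

As far as these compounds go, whether an amine or a carboxylic acid at this carbon would keep the number in that range stays open. No measurement on hand speaks to what lies behind this result.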